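The source may report more compounds than this note shows. Statements on the series, on what has been measured and on what is new or still open speak of the compounds shown alone.

In a physicochemical assay for lipophilicity, read by HPLC, at pH 7.5 (on this read-out lower numbers stand for lower lipophilicity and higher numbers for higher lipophilicity), compound 3 `CC[C@@H](Nc1c(C#N)c(-c2ccc(-c3ccccc3CO)cc2)nc2cnccc12)C(N)=O` gives 2.1, the second highest of the three numbers recorded. Compound 1 `CC[C@@H](Nc1c(C#N)c(-c2ccc(-c3cccnc3C)cc2)nc2cnccc12)C(N)=O` gives 1.9, and the step of a number 0.20 log units higher from compound 1 to compound 3 (within the scatter) lies within the scatter. Compound 2 `CCOc1ccccc1-c1ccc(-c2nc3cnccc3c(N[C@H](CC)C(N)=O)c2C#N)cc1` gives 3, and the step of a number 0.90 log units lower from compound 2 to compound 3 (beyond the scatter) lies beyond it. Compound 4 `CC[C@@H](Nc1c(C#N)c(-c2ccc(-c3cccc(OC)c3)cc2)nc2cnccc12)C(N)=O` differs from compound 3 in one place: 3-methoxyphenyl in place of 2-(hydroxymethyl)phenyl on an aromatic carbon. The step of a number 0.90 log units lower from compound 2 to compound 3 (beyond the scatter) bears most on this change, since compound 4 again carries an ether and no hydrogen-bond donor, as compound 2 does, with methoxy where compound 2 has ethoxy. A rise short of that step, yet beyond the scatter, is therefore expected, a number 0.50 log units higher from compound 3 to compound 4 (beyond the scatter). Compound 4 is estimated at 2.6, in a range from 2.2 to 3.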

Compound 4, distribution coefficient: 2.7
Beside the measured number, compound 4's estimate is 0.10 log units below it; measured number inside the range.
By their numbers in this assay, from the lowest: compounds 1 and 3 (each within the scatter of the next); then compounds 4 and 2 (each within the scatter of the next).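

Within this assay, 3-methoxyphenyl and 2-(hydroxymethyl)phenyl hold the same atoms joined differently, yet the swap gives a number 0.60 log units higher from compound 3 to compound 4 (beyond the scatter) at this place, so the atoms alone do not set the number. With a number 0.30 log units lower from compound 2 to compound 4 (within the scatter) the 3-methoxyphenyl and 2-ethoxyphenyl groups cannot be told apart here. The step of a number 0.80 log units higher from compound 1 to compound 4 (beyond the scatter) separates 3-methoxyphenyl from 2-methylpyridin-3-yl as well. Going by these compounds, whether an amine or a carboxylic acid on this ring would move the number further stays open. Nothing measured here gives a reason for these steps.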